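Working notes: from compound 3 to compound 4

The source may hold more compounds than are shown below. What is called first, only, known or untested is meant among the compounds shown, and "the series" means these compounds.

Values in a functional assay on KB cells (Homo sapiens) for cytotoxicity, read by MTT assay, with a stated time of 3 days; a higher number here means a weaker inhibitor, a lower number a stronger inhibitor
compound 1 `CCNc1nc(SCc2nc3ccccc3[nH]2)nc(-c2ccccc2)c1C#N` gives 7.35 nM
compound 2 `N#Cc1c(Nc2nccs2)nc(SCc2nc3ccccc3[nH]2)nc1-c1ccccc1` gives 14.7 nM
compound 3 `N#Cc1c(NC(N)=S)nc(SCc2nc3ccccc3[nH]2)nc1-c1ccccc1` gives 3.2 nM

Compound 3 has the lowest number of the three, and both others stand above it beyond the scatter. Compound 4 `N#Cc1c(-c2ccccc2)nc(SCc2nc3ccccc3[nH]2)nc1N1CCNCC1` carries piperazin-1-yl on the same aromatic carbon, ortho to a cyano group: a group of 6 heavy atoms (4 carbon, 2 nitrogen; one six-membered non-aromatic ring with 2 hetero atoms) in place of a group of 4 heavy atoms (1 carbon, 2 nitrogen, 1 sulfur; no ring), on an aromatic carbon. The measured steps at this place are modest: a 2.3-fold lower number from compound 1 to compound 3 (0.36 log units; beyond the scatter) and a 4.6-fold lower number from compound 2 to compound 3 (0.66 log units; beyond the scatter), with a 2.0-fold higher number from compound 1 to compound 2 (0.30 log units; within the scatter) as the third. Compound 3 holds the low end at 3.2 nM, so a modest upward step is expected in this assay. The expected step is a 2.5-fold higher number from compound 3 to compound 4 (0.40 log units; beyond the scatter). For compound 4 the estimated value is 8 nM, with an expected range of 2.5 nM to 30 nM.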

Compound 4, half-maximal inhibitory concentration: 2.87 nM
Compound 4: middle estimate off by 2.8-fold (0.45 log units), on the high side; the range from low to high includes it.
By their numbers in this assay, from the lowest: compounds 4 and 3 (each within the scatter of the next); then compounds 1 and 2 (each within the scatter of the next).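

In this assay, the aromatic carbon ortho to a cyano group accepts piperazin-1-yl, a six-membered non-aromatic ring, in place of the open-chain group of compound 3, with a 1.1-fold lower number from compound 3 to compound 4 (0.05 log units; within the scatter). The ring also reads lower than the other two groups at this place, with a 5.1-fold lower number from compound 2 to compound 4 (0.71 log units; beyond the scatter) and a 2.6-fold lower number from compound 1 to compound 4 (0.41 log units; beyond the scatter), so two quite different groups now share the low end. No evidence on the reason for this is at hand.

The compounds shown leave open whether the second ring nitrogen of piperazin-1-yl matters, as morpholin-4-yl or 4-methylpiperazin-1-yl at this place would show.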